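Swapping the benzyl substituent in a benzamide series

A few compounds are considered here, and "the series" means these few. Any claim that something is new, unique, unknown or untested is made for them only; others in the source may bear on it.

Compound 3 `CC(Oc1ccnc(Nc2cnn(C3CCN(C)CC3)c2)c1)c1cccc(C(=O)NCc2ccc(Cl)c(C(F)(F)F)c2)c1` gives 8000 nM in a functional assay on NCI-H3122 cells (Homo sapiens) for antiproliferative activity, read by MTT assay, with a stated time of 48 h (on this read-out lower numbers stand for stronger inhibition and higher numbers for weaker inhibition), the lowest of the three numbers measured, although compound 2 `Cc1ccc(CNC(=O)c2cccc(C(C)Oc3ccnc(Nc4cnn(C5CCN(C)CC5)c4)c3)c2)cc1`, with 8900 nM, sits within the scatter of it; only compound 1 `COc1ccc(CNC(=O)c2cccc(C(C)Oc3ccnc(Nc4cnn(C)c4)c3)c2)cc1OC`, with 38500 nM, lies clearly higher. The unmeasured compound 4 `COc1ccc(CNC(=O)c2cccc(C(C)Oc3ccnc(Nc4cnn(C5CCN(C)CC5)c4)c3)c2)cc1OC` differs from compound 3 by 3,4-dimethoxyphenyl in place of 4-chloro-3-(trifluoromethyl)phenyl on a saturated chain carbon bound to an amide-type nitrogen. Among the measured compounds shown here, the one measured step bearing on that place is a 1.1-fold lower number from compound 2 to compound 3 (0.05 log units; within the scatter), which shows that exchanging one substituted benzyl group for another changed little. Compound 1 carries the same 3,4-dimethoxybenzyl group as compound 4 but differs from it in a second place, so its value cannot be laid directly against compound 3. On that basis the step from compound 3 to compound 4 is expected to stay within the scatter, a 1.5-fold higher number from compound 3 to compound 4 (0.18 log units; within the scatter), with some allowance for a drift toward the higher number of compound 1. Compound 4 is therefore estimated at 12000 nM in this assay, in a range from 5000 nM to 30000 nM.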

Compound 4, half-maximal inhibitory concentration: 14800 nM
The estimate for compound 4 lay 1.2-fold (0.09 log units) below the measured number; the measured number falls inside the stated range.
By their numbers in this assay, from the lowest: compounds 3, 2 and 4 (each within the scatter of the next); then compound 1.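

In this assay, the 3,4-dimethoxyphenyl group on a saturated chain carbon bound to an amide-type nitrogen stays within the scatter of both other groups at that place, with a 1.9-fold higher number from compound 3 to compound 4 (0.27 log units; within the scatter) and a 1.7-fold higher number from compound 2 to compound 4 (0.22 log units; within the scatter), so these three substituted phenyl groups cannot be told apart here. Compound 4 also gives a reading of the second place, on the aromatic nitrogen, with the 3,4-dimethoxybenzyl group held constant: 1-methylpiperidin-4-yl in place of methyl goes with a 2.6-fold lower number from compound 1 to compound 4 (0.42 log units; beyond the scatter), a modest step. Nothing available explains the size of either step.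

As far as these compounds go, it remains open whether a benzyl group carrying an amine or a carboxylic acid would move the number beyond the scatter. From the compounds shown here alone, it is also open whether a morpholine ring on the aromatic nitrogen would match 1-methylpiperidin-4-yl.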